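Replacing 2,4,6-trimethylphenyl: from compound 3 to compound 4

The source may hold more compounds than are shown below. What is called first, only, known or untested is meant among the compounds shown, and "the series" means these compounds.

Measured so far in an ADME assay on L02 cells (Homo sapiens) for inhibition, read by CCK-8 assay, with a stated time of 48 h; on this read-out lower numbers stand for stronger inhibition of growth and higher numbers for weaker inhibition of growth
compound 1 `CN1CCN(c2ccc(Nc3ncc(Cl)c(NCc4ccccc4)n3)nc2)CC1` gives 20300 nM
compound 2 `Cc1cccc(Nc2nc(Nc3ccc(N4CCN(C)CC4)cn3)ncc2Cl)c1` gives 6080 nM
compound 3 `Cc1cc(C)c(Nc2nc(Nc3ccc(N4CCN(C)CC4)cn3)ncc2Cl)c(C)c1` gives 20500 nM

Compound 3 sits at the high end of these numbers, level with compound 1, as a 1.0-fold higher number from compound 1 to compound 3 (0.00 log units; within the scatter) shows. Compound 2 stands clearly apart from it, with a 3.4-fold higher number from compound 2 to compound 3 (0.53 log units; beyond the scatter) as the measured gap.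

The next change leads to compound 4 `COc1ccc(Nc2nc(Nc3ccc(N4CCN(C)CC4)cn3)ncc2Cl)cc1` and reads: 4-methoxyphenyl in place of 2,4,6-trimethylphenyl on a nitrogen on an aromatic ring. In words, 4-methoxyphenyl comes in place of 2,4,6-trimethylphenyl on a nitrogen on an aromatic ring.

Within the data shown here, no measured compound carries 4-methoxyphenyl, so any expectation is an extrapolation. The closest guide is compound 2, with 3-methylphenyl at the same place, and a 3.4-fold higher number from compound 2 to compound 3 (0.53 log units; beyond the scatter) is the step that bears most directly. The step of a 3.3-fold lower number from compound 1 to compound 2 (0.52 log units; beyond the scatter) points the same way and has a similar size. Leaving 2,4,6-trimethylphenyl is thus expected to bring the number back towards that of compound 2, though the two groups differ, and the data do not show how far that comparison holds.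

In this assay the expected step is a 2.6-fold lower number from compound 3 to compound 4 (0.41 log units; beyond the scatter), modest in size and towards a lower number. For compound 4 the estimate is 8000 nM, with an expected range from 3000 nM to 20000 nM, and the upper end stays close to compound 3.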

Compound 4, concentration for 50% growth inhibition: 3150 nM
Compound 4: middle estimate off by 2.5-fold (0.40 log units), on the high side; measured number inside the range.
By their numbers in this assay, from the lowest: compounds 4 and 2 (each within the scatter of the next); then compounds 1 and 3 (each within the scatter of the next).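

In this assay, among these compounds, the place on a nitrogen on an aromatic ring accepts 4-methoxyphenyl, the first group here with a hydrogen-bond acceptor, and this change separates compound 4 from both 2,4,6-trimethylphenyl (a 6.5-fold lower number from compound 3 to compound 4 (0.81 log units; beyond the scatter)) and benzyl (a 6.4-fold lower number from compound 1 to compound 4 (0.81 log units; beyond the scatter)). Against 3-methylphenyl the change does not separate the two compounds (a 1.9-fold lower number from compound 2 to compound 4 (0.29 log units; within the scatter)), so two differently substituted phenyl groups now read alike, and compounds 2 and 4 form a pair apart from compounds 1 and 3. Nothing available on these compounds gives a reason for this split.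

Going by these compounds, it remains open whether the level shared by compounds 2 and 4 is a limit for this place or whether other groups can pass it, for example an unsubstituted phenyl, a 4-hydroxyphenyl or a phenyl carrying an amine or a carboxylic acid. Also open, on these data alone, is whether a longer chain between the nitrogen and the phenyl ring than the one in benzyl would read like compound 1.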